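Phenyl to Pyridin-2-yl in Compound 4

The compounds below may be only part of what the source reports. "The series", "measured", "known", "first", "only" and "open" are said of these compounds alone.

Of the compounds shown here, three of a shared core have been measured in a functional assay on cardiac atrium for agonist activity at histamine H2 receptor (Cavia porcellus); a higher number here means a larger maximal response, a lower number a smaller maximal response. Compound 1 `N=C(NCCCc1c[nH]cn1)NC(=O)CC(c1ccccc1)c1ccccc1` gives 85%, the highest of the three numbers. Compound 2 `N=C(NCCCc1c[nH]cn1)NC(=O)C(c1ccccc1)c1ccccc1` gives 69%, lower than compound 1 by a margin beyond the usual scatter. Compound 3 `N=C(NCCCc1c[nH]cn1)NC(=O)CC(c1ccc(Br)cc1)c1ccc(Br)cc1` gives 60%, the lowest of the three and also beyond the scatter below compound 1. Both gaps exceed the scatter. Compound 1 thus shows the largest maximal response of the three. Among the measured compounds shown here, no two measured compounds differ in only one place, so no single step between them can be computed.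

Compound 4 `N=C(NCCCc1c[nH]cn1)NC(=O)CC(c1ccccc1)c1ccccn1` has not been measured. Relative to compound 1 it differs as pyridin-2-yl in place of phenyl on a saturated chain carbon bound to an aromatic carbon and a saturated chain carbon. For the measured compounds named here, no measured pair shows what such a change does here, so the expectation rests on compound 1 alone. The step from compound 1 to compound 4 is estimated as a number 10 percentage points lower from compound 1 to compound 4 (within the scatter), a small decrease close to the scatter. Compound 4 is therefore expected to give about 75% in this assay, within a range from 55% to 95%.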

Compound 4, largest response reached (Emax), in percent of the reference or control that the assay uses: 97%
Compound 4: middle estimate off by 22 percentage points, on the low side; measured number above the stated range.
By their numbers in this assay, from the lowest: compounds 3 and 2 (each within the scatter of the next); then compound 1; then compound 4.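

In this assay, pyridin-2-yl in place of phenyl on a saturated chain carbon bound to an aromatic carbon and a saturated chain carbon gives a number 12 percentage points higher from compound 1 to compound 4 (beyond the scatter) as the first single-place step readable in this series. It shows that one of the two phenyl groups at this carbon can give way to a ring carrying one nitrogen and one hydrogen-bond acceptor without any loss of maximal response, and with a gain here. Nothing measured on these compounds accounts for that gain.

Going by these compounds, what remains open is whether the gain belongs to pyridin-2-yl specifically or would also appear with pyridin-3-yl, pyridin-4-yl or a thiazole ring. Also open, on these data alone, is what a second pyridin-2-yl in place of the remaining phenyl would do, and whether the same exchange carries over to the shorter chain of compound 2 or the bromophenyl groups of compound 3.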